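Side-chain esters of a shared core: cytotoxicity notes

The source may report more compounds than this note shows. Statements on the series, on what has been measured and on what is new or still open speak of the compounds shown alone.

Measured in an ADME assay on HepG2 2.2.15 cells (Homo sapiens) for cytotoxicity, read by MTT assay (a lower number here means that less compound is tolerated, a higher number that more compound is tolerated), so far:
compound 1 `C=C1CC[C@@H]2[C@](C)(COC(=O)c3cccs3)[C@H](O)CC[C@@]2(C)[C@@H]1/C=C/C1=CCOC1=O` gives 557000 nM
compound 2 `C=C1CC[C@@H]2[C@](C)(COC(=O)c3cc(=O)c4ccccc4o3)[C@H](O)CC[C@@]2(C)[C@@H]1/C=C/C1=CCOC1=O` gives 171000 nM
compound 3 `C=C1CC[C@@H]2[C@](C)(COC(C)=O)[C@H](O)CC[C@@]2(C)[C@@H]1/C=C/C1=CCOC1=O` gives 225000 nM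

Compound 3 holds the second highest of the three numbers. Compound 2 sits closest to it, and the gap a 1.3-fold higher number from compound 2 to compound 3 (0.12 log units; within the scatter) does not exceed the scatter, so no order between compound 2 and compound 3 can be claimed. Compound 1 lies furthest away, the separation being a 2.5-fold lower number from compound 1 to compound 3 (0.39 log units; beyond the scatter). The other measured step, a 3.3-fold lower number from compound 1 to compound 2 (0.51 log units; beyond the scatter), likewise concerns only the group on the carbonyl carbon of the ester.

Compound 4 `C=C1CC[C@@H]2[C@](C)(COC(C)=O)[C@H](OC(C)=O)CC[C@@]2(C)[C@@H]1/C=C/C1=CCOC1=O` is the next structure. Its difference from compound 3 is acetyl in place of hydrogen on an oxygen on a saturated carbon; cut one bond further out, it reads hydroxy to acetoxy. None of the three measured steps touches this oxygen on a saturated carbon: all of them exchange the group on the carbonyl carbon, and even the largest of those, a 3.3-fold lower number from compound 1 to compound 2 (0.51 log units; beyond the scatter), stays modest. For the measured compounds named here, there is therefore no measured step that bears directly on the change to compound 4, and the expectation for this assay is a step of a 1.1-fold lower number from compound 3 to compound 4 (0.05 log units; within the scatter) that does not clear the scatter. For compound 4 the estimated value is 200000 nM, with a range from 100000 nM to 450000 nM.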

Compound 4, half-maximal cytotoxic concentration: 757000 nM
Compound 4: middle estimate off by 3.8-fold (0.58 log units), on the low side; the measured number lies above the stated range.
By their numbers in this assay, from the lowest: compounds 2 and 3 (each within the scatter of the next); then compounds 1 and 4 (each within the scatter of the next).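

For the compounds shown here, the oxygen on a saturated carbon is the first place outside the group on the carbonyl carbon where a change is seen to move the number in this assay: hydroxy to acetoxy gives a 3.4-fold higher number from compound 3 to compound 4 (0.53 log units; beyond the scatter), a step beyond the scatter and so a real one for this series. Its size is close to that of a 3.3-fold lower number from compound 1 to compound 2 (0.51 log units; beyond the scatter), but it runs the other way, towards more compound tolerated, so this oxygen counts as a site of change in its own right and not as a silent position. Nothing measured in this set accounts for the rise, so only its size and direction can be recorded.

Acetyl is the only group shown on this oxygen, so it remains open whether a longer chain such as butanoyl, an aromatic acyl group such as benzoyl, or a simple methyl ether would give a step of the same direction. On these data alone, it is also open whether acetoxy in place of hydroxy would raise the number to the same extent when the ester on the carbonyl carbon carries thiophen-2-yl, as in compound 1, and not methyl.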